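Swapping the Ester Tail on a Shared Core

This account rests on a few compounds, and the source may have more. Where it says the series, first, only, none or still open, it means among the compounds named here.

The account follows a small series tested in a functional assay on MDA-MB-231 cells (Homo sapiens) for antiproliferative activity, read by MTT assay, with a stated time of 72 h; on this read-out lower numbers stand for stronger inhibition and higher numbers for weaker inhibition. Compound 1, `CC1=CC[C@H]2[C@@H]1CC=C(C)[C@@H](CC[C@H]1[C@]3(C)CC[C@H](O)C(C)(C)O[C@H]3CC[C@@]1(C)O)C2(C)C`, reaches only the limit of > 50000 nM in this assay, which is a limit of the assay rather than a number. Compound 2, `CC1=CC[C@H]2[C@H](CC[C@]2(C)O)C(C)(C)[C@@H]1CC[C@H]1[C@]2(C)CC[C@H](OC(=O)CCC(=O)O)C(C)(C)O[C@H]2CC[C@@]1(C)O`, gives 27900 nM in this assay and holds the only number shown. Among the compounds with values here, the one other value, that of compound 1, is a limit (the limit of > 50000 nM in this assay, at which 1 of the 2 values shown sits). Compound 3, `CC1=CC[C@H]2[C@H](CC[C@]2(C)O)C(C)(C)[C@@H]1CC[C@H]1[C@]2(C)CC[C@H](OC(=O)c3ccc(C)cc3)C(C)(C)O[C@H]2CC[C@@]1(C)O`, is not yet measured and differs from compound 2 in one place: 4-methylphenyl in place of 2-carboxyethyl on a carbonyl carbon. No step between measured compounds is shown, so the expectation rests on the change alone. The step from compound 2 to compound 3 is expected to be modest, toward stronger inhibition, and is estimated as a 2.3-fold lower number from compound 2 to compound 3 (0.37 log units; beyond the scatter). Compound 3 is expected to give about 12000 nM in this assay, with a range from 4000 nM to 40000 nM.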

Compound 3, half-maximal inhibitory concentration: 33400 nM
Compound 3: the middle estimate sits 2.8-fold (0.44 log units) below what was measured; measured number inside the range.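

In this assay, the change on a carbonyl carbon whose other neighbours are oxygen next to a carbonyl group gives a 1.2-fold higher number from compound 2 to compound 3 (0.08 log units; within the scatter). Within the data shown here, this is the first step that can be read, and it shows that the read-out does not separate 2-carboxyethyl from 4-methylphenyl at this place, even though the first has no ring and carries a hydrogen-bond donor and acceptor, while the second has a six-membered aromatic ring of carbon only and carries neither. Compound 1 stays a limit of the assay and not a number, so it adds no step here: the limit of > 50000 nM in this assay, at which 1 of the 3 values shown sits.

The compounds shown leave open whether a chain ending in an amine, a longer chain or a pyridine ring on this carbonyl carbon would read any differently. They also leave open whether 2-carboxyethyl and 4-methylphenyl would read alike on another core.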